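A few compounds are considered here, and "the series" means these few. Any claim that something is new, unique, unknown or untested is made for them only; others in the source may bear on it.

Series notes. Compound 1 `CCN(CC)S(=O)(=O)c1ccc(S(=O)(=O)N2CCC[C@@H](C(=O)N[C@H]3CC[C@@H](OC)CC3)C2)cc1` gives 960 nM in a functional assay on MIA PaCa-2 cells (Homo sapiens) for inhibition, read by MTT assay, with a stated time of 7 days; on this read-out higher numbers stand for weaker inhibition and lower numbers for stronger inhibition; compound 2 `CCN(CC)S(=O)(=O)c1ccc(S(=O)(=O)N2CCC[C@@H](C(=O)N3CCC(F)(F)CC3)C2)cc1` gives 16 nM; compound 3 `CCN(CC)S(=O)(=O)c1ccc(S(=O)(=O)N2CCC[C@@H](C(=O)N3CCS(=O)(=O)CC3)C2)cc1` gives 900 nM. Compound 3 therefore sits second highest of the three: a 1.1-fold lower number from compound 1 to compound 3 (0.03 log units; within the scatter), whereas a 56-fold higher number from compound 2 to compound 3 (1.75 log units; beyond the scatter). Compound 4 `CCN(CC)S(=O)(=O)c1ccc(S(=O)(=O)N2CCC[C@@H](C(=O)N3CC[C@H](OC)C3)C2)cc1` is the next variant: 3-methoxypyrrolidin-1-yl in place of 1,1-dioxothiomorpholin-4-yl on a carbonyl carbon. For the measured compounds named here, two measured steps bear on this: a 56-fold higher number from compound 2 to compound 3 (1.75 log units; beyond the scatter) and a 60-fold lower number from compound 1 to compound 2 (1.78 log units; beyond the scatter) show that the amide position moves the number a long way, while compound 1, the other methoxy-bearing amide, and compound 3 sit together. Compound 4 keeps a cyclic tertiary amide, as compound 2 does, but carries a methoxy ether as compound 1 does, so the two precedents pull in opposite directions. For compound 4 a moderate step toward a lower number is expected, a 3.6-fold lower number from compound 3 to compound 4 (0.56 log units; beyond the scatter), with wide uncertainty. Compound 4 is estimated at 250 nM, between 40 nM and 1500 nM.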

Compound 4, half-maximal inhibitory concentration: 2460 nM
Compound 4: middle estimate off by 9.8-fold (0.99 log units), on the low side; measured number outside the range, above it.
By their numbers in this assay, from the lowest: compound 2; then compounds 3 and 1 (each within the scatter of the next); then compound 4.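

In this assay, a ring amide on the carbonyl carbon does not by itself give the low number: a 150-fold higher number from compound 2 to compound 4 (2.19 log units; beyond the scatter). Beside that, a 2.7-fold higher number from compound 3 to compound 4 (0.44 log units; beyond the scatter) and a 2.6-fold higher number from compound 1 to compound 4 (0.41 log units; beyond the scatter) are modest steps, which leaves compound 2 alone at the low end of the four. No measurement shown accounts for this spread. On these data alone, how a plain piperidin-1-yl or a 4,4-dimethylpiperidin-1-yl on the carbonyl carbon would read stays open, so the fluorines and the carbon framework of 4,4-difluoropiperidin-1-yl cannot yet be separated.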